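This account rests on a few compounds, and the source may have more. Where it says the series, first, only, none or still open, it means among the compounds named here.

Compound 1 `N#CC1=C(N)N(c2ccc(S(N)(=O)=O)cc2)C2=C(C(=O)CCC2)C1c1ccc(Cl)cc1Cl` carries a free amine on its shared core. In a functional assay on Ehrlich cells (Mus musculus) for cytotoxicity, read by trypan blue exclusion, with a stated time of 2 h (on this read-out lower numbers stand for stronger inhibition and higher numbers for weaker inhibition), compound 1 gives 25 ug/mL. Compound 2 `Cc1ccc(C(=O)NC2=C(C#N)C(c3ccc(Cl)cc3Cl)C3=C(CCCC3=O)N2c2ccc(S(N)(=O)=O)cc2)cc1` differs from it only in that the amine is capped as an amide. In this assay compound 2 reaches only > 100 ug/mL, which is a limit of the assay and not a number; this is the case described by the limit of > 100 ug/mL in this assay, at which 1 of the 2 values shown sits. The step of an at least 4.0-fold higher number from compound 1 to compound 2 (0.60 log units; beyond the scatter) is therefore at least modest, and it points towards weaker inhibition.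

Compound 3 `N#CC1=C(NC(=O)/C=C/c2ccccc2)N(c2ccc(S(N)(=O)=O)cc2)C2=C(C(=O)CCC2)C1c1ccc(Cl)cc1Cl` keeps that amide and changes only the group on its carbonyl carbon: 2-phenylethenyl in place of 4-methylphenyl on a carbonyl carbon. Among the compounds with values here, no measured pair shows what such a swap within an amide does; the only step that bears on compound 3 is the one from compound 1 to compound 2, which shows that the amide itself already carries the number past the limit. Compound 3 is therefore expected to sit near compound 2, and the expected step that the limit leaves unreadable from compound 2 to compound 3 is small. The estimated value of compound 3 in this assay is 120 ug/mL, within a range from 40 ug/mL to 300 ug/mL, with a fair chance that the assay again reports only a limit.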

Compound 3, half-maximal inhibitory concentration: > 100 ug/mL
Compound 3: only a limit was reported; the forecaster's own chance of this, stated with the estimate: 60%; the middle value lies beyond the limit too.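

Capping the free amine with (2-phenylethenyl)carbonyl in place of hydrogen gives an at least 4.0-fold higher number from compound 1 to compound 3 (0.60 log units; beyond the scatter), so the move towards weaker inhibition first seen with the (4-methylphenyl)carbonyl amide does not depend on that one group. With two different amides now behaving alike, and neither going against the trend, the loss of the free amine hydrogen or the presence of an amide at this nitrogen looks like the shared feature, although two compounds are a small basis for that pattern. Compound 2 and compound 3 both sit at a limit and not at a number, so the step between them cannot be read and any difference between 4-methylphenyl and 2-phenylethenyl on the carbonyl carbon stays hidden: the limit of > 100 ug/mL in this assay, at which 2 of the 3 values shown sit.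

As far as these compounds go, how far past the limit each amide lies remains unknown, and so the two cannot be ranked against each other. Also open, from the compounds shown here alone, is whether a much smaller cap on the same nitrogen, such as an acetyl group, or a plain methyl group with no carbonyl at all, would keep a readable number like that of compound 1.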